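This account rests on a few compounds, and the source may have more. Where it says the series, first, only, none or still open, it means among the compounds named here.

Measured so far in a functional assay on MDA-MB-435 cells (Homo sapiens) for cytotoxicity, read by MTT assay, with a stated time of 72 h; a higher number here means a weaker inhibitor, a lower number a stronger inhibitor:

compound 1, `N[C@H]1CC[C@H](Nc2c(C(=O)NCc3ccc(Cl)cc3)nc(Br)c3cccnc23)CC1`: 1000 nM
compound 2, `COC(=O)CNc1c(C(=O)NCc2ccc(F)cc2)nc(Br)c2cccnc12`: 10000 nM

Compound 1 stands at the lowest number of the two; compound 2 gives the higher number, and the gap between the two values is beyond the scatter. Among the compounds with values here, the two compounds differ at more than one place, so no single-change step is available among the measured compounds, and nothing measured so far shows how a change at the 4-chlorobenzyl end of compound 1 reads in this assay.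

Compound 3, `N[C@H]1CC[C@H](Nc2c(C(=O)NCc3ccccc3)nc(Br)c3cccnc23)CC1`, is compound 1 with one change: hydrogen in place of chloro on an aromatic carbon, that is, 4-chlorobenzyl to benzyl on the amide. Within the data shown here, no measured pair gives a size for this kind of step. Loss of one heavy atom at the outer end of the amide side chain is expected to move the value little, most likely a step of no more than modest size towards a higher number, or none beyond the scatter. Compound 3 is therefore estimated at 1600 nM, within 500 nM to 5000 nM, an expected step of a 1.6-fold higher number from compound 1 to compound 3 (0.20 log units; within the scatter).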

Compound 3, half-maximal inhibitory concentration: 7000 nM
Compound 3: the middle estimate sits 4.4-fold (0.64 log units) below what was measured; measured number above the stated range.
By their numbers in this assay, from the lowest: compound 1; then compounds 3 and 2 (each within the scatter of the next).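

In this assay, within the data shown here, the change from 4-chlorobenzyl to benzyl on the amide gives the first single-place step, a 7.0-fold higher number from compound 1 to compound 3 (0.85 log units; beyond the scatter), and so shows that this position is not silent. With the rest of compound 1 held fixed, the loss of one chlorine on an aromatic carbon, para to a large group, is enough to carry the value beyond the scatter, so the outer end of the amide side chain counts in this assay alongside whatever sets the value elsewhere in the molecule. Nothing at hand gives a measured reason for the size of this step.

Still open, from the compounds shown here alone, is whether the lower number of compound 1 belongs to chlorine itself or to any group on that aromatic carbon, which methyl, methoxy or nitrile in the same place would settle. Also open, going by these compounds, is how much the amino side chain on the shared core of compound 1 contributes, which a longer chain or a carboxylic acid at that point, with the 4-chlorobenzyl amide kept, would show.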